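Hydrogen in place of methyl on compound 2

This account rests on a few compounds, and the source may have more. Where it says the series, first, only, none or still open, it means among the compounds named here.

In an ADME assay on the whole organism (Mus musculus, strain C57BL6/N), read by LC-MS, with a stated time of 24 h, at a dose of 50 mg/kg by the oral route (on this read-out higher numbers stand for higher exposure at the dose given and lower numbers for lower exposure), compound 1 (`NC(=O)c1cnc2c(c1Cl)CCN2`) gives 4330 ng.h/mL and compound 2 (`C[C@@H]1Cc2cc(C(N)=O)cnc2N1`) gives 5120 ng.h/mL within the usual scatter of each other, so compound 2 stands level with compound 1. Compound 3 (`NC(=O)c1cnc2c(c1)CCN2`) brings one change to compound 2 (hydrogen in place of methyl on a saturated ring carbon): hydrogen in place of methyl on a saturated ring carbon. Among the compounds with values here, no pair of measured compounds shows this change on its own, so the data give no size for it, and no step beyond the scatter is expected. The estimated change (a 1.1-fold lower number from compound 2 to compound 3 (0.06 log units; within the scatter)) stays small. For compound 3 the estimated value is 4500 ng.h/mL (range 1800 ng.h/mL to 10000 ng.h/mL).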

Compound 3, area under the concentration-time curve: 29000 ng.h/mL
Estimate against measurement, compound 3: 6.4-fold (0.81 log units) below; measured number above the stated range.
By their numbers in this assay, from the lowest: compounds 1 and 2 (each within the scatter of the next); then compound 3.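

In this assay the removal of the methyl on a saturated ring carbon gives a 5.7-fold higher number from compound 2 to compound 3 (0.75 log units; beyond the scatter) and stands beside a 6.7-fold higher number from compound 1 to compound 3 (0.83 log units; beyond the scatter) for hydrogen in place of chloro on an aromatic carbon. Each group, at its own place, thus goes with a lower number than hydrogen does, which compound 1 and compound 2 could not show while they stood level with each other. Nothing shown gives a reason for either step. Going by these compounds, whether a smaller group such as fluoro on the aromatic carbon, or a hydroxyl on the saturated ring carbon, would keep the higher number stays open.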